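Solubility of compound 3 without the carboxythiophene

A few compounds are considered here, and "the series" means these few. Any claim that something is new, unique, unknown or untested is made for them only; others in the source may bear on it.

Measured in a physicochemical assay for solubility, in phosphate buffer, with a stated time of 18 h; a higher number here means a more soluble compound, a lower number a less soluble compound:
- compound 1 `CSc1nc(C(C)(C)C)nc2nc(N)c(C#N)c(N)c12`: 14000 nM
- compound 2 `CC(C)(C)c1nc(-c2ccc(C(=O)O)s2)c2c(N)c(C#N)c(N)nc2n1`: > 1000000 nM (a limit of the assay, not a number)

Compound 2 stands at the limit of > 1000000 nM in this assay, at which 1 of the 2 values shown sits, so its position is known only as a limit. The next compound is compound 3 `CC(C)(C)c1nc(-c2ncco2)c2c(N)c(C#N)c(N)nc2n1`, with 1,3-oxazol-2-yl in place of 5-carboxythiophen-2-yl on an aromatic carbon. Among the measured compounds shown here, one measured step bears on this change. With 5-carboxythiophen-2-yl in place of methylsulfanyl, this assay showed an at least 71-fold higher number from compound 1 to compound 2 (1.85 log units; beyond the scatter), a large step. Compound 3 loses that same group, so a large step to a lower number is expected, back towards the level of compound 1 at 14000 nM. For the measured compounds named here, no measured compound carries 1,3-oxazol-2-yl, so the size of the fall remains uncertain. The expected change is an at least 28-fold lower number from compound 2 to compound 3 (1.45 log units; beyond the scatter). For compound 3 the estimated value is 35000 nM. The expected range for compound 3 runs from 8000 nM to 150000 nM.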

Compound 3, solubility: 50000 nM
Compound 3: the middle estimate sits 1.4-fold (0.15 log units) below what was measured; the range from low to high includes it.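

In this assay, the position opposite the ring nitrogen now carries a third group, and 1,3-oxazol-2-yl gives a 3.6-fold higher number from compound 1 to compound 3 (0.55 log units; beyond the scatter). A ring without a carboxylic acid therefore still ends higher than methylsulfanyl, although the same change of group also gives an at least 20-fold lower number from compound 2 to compound 3 (1.30 log units; beyond the scatter), and much of the large rise seen with 5-carboxythiophen-2-yl does not carry over to 1,3-oxazol-2-yl. Compound 2 is given only as a limit, and the size of this fall stays open on that side: the limit of > 1000000 nM in this assay, at which 1 of the 3 values shown sits.

From the compounds shown here alone, whether the carboxylic acid or the thiophene ring carries the high number of compound 2 remains open; compound 3 changes both at once. The compounds shown do not tell how thiophen-2-yl without the carboxylic acid, 1,3-oxazol-2-yl carrying a carboxylic acid, or an amine at this position would stand in this assay.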